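The source may report more compounds than this note shows. Statements on the series, on what has been measured and on what is new or still open speak of the compounds shown alone.

Measured compounds in a functional assay on T47D cells (Homo sapiens) for inhibition; on this read-out lower numbers stand for stronger inhibition and higher numbers for weaker inhibition:
- compound 1, `Oc1ccc(-c2cc(-c3ccccc3F)cc(-c3ccc(O)cc3)n2)cc1`: 15100 nM
- compound 2, `Oc1ccc(-c2cc(-c3ccc(F)cc3)cc(-c3ccc(O)cc3)n2)cc1`: 5260 nM
- compound 3, `Oc1ccc(-c2cc(-c3ccccc3C(F)(F)F)cc(-c3ccccc3O)n2)cc1`: 7180 nM

Compound 3 stands second highest of the three numbers; against compound 2 it lies within the scatter, against compound 1 the gap is beyond the scatter. Compound 4, `Oc1ccc(-c2cc(-c3ccccc3C(F)(F)F)cc(-c3ccc(O)cc3)n2)cc1`, differs from compound 3 by 4-hydroxyphenyl in place of 2-hydroxyphenyl on an aromatic carbon. Within the data shown here, no measured step covers this change: the one measured step, a 2.9-fold lower number from compound 1 to compound 2 (0.46 log units; beyond the scatter), concerns the fluorophenyl and is modest. Compounds 1 and 2 both carry two 4-hydroxyphenyl groups and span a range that includes the number of compound 3, so the two hydroxyphenyl arrangements are not separated by the data. For compound 4 in this assay a step of no more than modest size is therefore expected, in either direction, with a slight lean toward a lower number, which is the expectation behind a 1.4-fold lower number from compound 3 to compound 4 (0.16 log units; within the scatter). Compound 4 is estimated at 5000 nM, within 1500 nM to 16000 nM.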

Compound 4, half-maximal inhibitory concentration: > 50000 nM
Compound 4 gave a limit, no number (the forecaster's own chance of this, stated with the estimate: 5%); middle value at least 10-fold (1.00 log units) away from the limit.
By their numbers in this assay, from the lowest: compounds 2 and 3 (each within the scatter of the next); then compound 1. At a limit, above all of these: compound 4.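

In this assay compound 4 returns a limit of the assay and not a number: the limit of > 50000 nM in this assay, at which 1 of the 4 values shown sits. Among these compounds, on the carbon next to the ring nitrogen, with 2-(trifluoromethyl)phenyl kept, the hydroxyl position on the phenyl group now counts, a change no earlier pair covered: an at least 6.9-fold higher number from compound 3 to compound 4 (0.84 log units; beyond the scatter). With two 4-hydroxyphenyl groups kept, 2-(trifluoromethyl)phenyl also falls behind both fluorophenyl groups, an at least 9.5-fold higher number from compound 2 to compound 4 (0.97 log units; beyond the scatter) and an at least 3.3-fold higher number from compound 1 to compound 4 (0.51 log units; beyond the scatter), and among the compounds shown it gives a measured number only in compound 3, alongside 2-hydroxyphenyl.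

On these data alone, whether 2-hydroxyphenyl changes the number in the same way alongside 2-fluorophenyl or 4-fluorophenyl remains open. So does the outcome for a methoxy group or an amine in place of the hydroxyl on that phenyl group.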